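Chloro in place of hydrogen: compound 3 to compound 4

A few compounds are considered here, and "the series" means these few. Any claim that something is new, unique, unknown or untested is made for them only; others in the source may bear on it.

Three compounds share a core in which two amine-linked aromatic rings flank a central benzylic spacer. In a functional assay on MDA-MB-231 cells for antagonist activity at C-X-C chemokine receptor type 4 (Homo sapiens), tested at 10 nM (a lower number here means a weaker effect, a higher number a stronger effect of the compound at the concentration tested), compound 1 `Fc1ccccc1NCc1ccc(CNc2ccccc2F)cc1` gives 32%, compound 2 `Fc1cccc(NCc2ccc(CNc3cccc(F)n3)cc2)n1` gives 55%, and compound 3 `c1ccc(NCc2ccc(CNc3ncccn3)cc2)nc1` gives 58%. Compound 3 thus holds the highest number of the three, though compound 2 sits only a few points lower and within the scatter, so no order between those two can be read; compound 1 lies well below both, beyond the scatter.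

Compound 4 `Clc1cccc(NCc2ccc(CNc3ncccn3)cc2)n1` is not yet measured in this assay. It differs from compound 3 in one place: chloro in place of hydrogen on an aromatic carbon. The chloro sits next to the ring nitrogen and meta to a large group, so that the pyridin-2-yl becomes 6-chloropyridin-2-yl. Within the data shown here, no pair among the measured compounds isolates a change of this kind, so there is no single step to lean on; the only guide is that compound 2 and compound 3, which carry different small groups on the same ring, are indistinguishable in this assay.

The expectation is therefore a step from compound 3 to compound 4 of a number 2 percentage points higher from compound 3 to compound 4 (within the scatter), small and within the scatter, with no direction claimed. Compound 4 is estimated at 60%, in the range 42% to 76%.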

Compound 4, a percentage reported as inhibition, at one concentration (the size of the read-out at that concentration, not a potency): 100%
For compound 4 the middle estimate is 40 percentage points below the measured one; the whole stated range lies below it.
By their numbers in this assay, from the lowest: compound 1; then compounds 2 and 3 (each within the scatter of the next); then compound 4.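

Among these compounds, replacing pyridin-2-yl with 6-chloropyridin-2-yl gives, in this assay, a number 42 percentage points higher from compound 3 to compound 4 (beyond the scatter), and this is the first change that can be read in one place. The aromatic carbon next to the ring nitrogen therefore accepts a substituent and responds strongly to it: one chlorine atom, adding no hydrogen-bond donor or acceptor, accounts for the whole step. Nothing at hand bears on why this single atom has an effect of this size.

As far as these compounds go, it remains open whether the gain is specific to chloro or extends to other groups on the same carbon, such as a methyl, a methoxy, an amine or a nitrile, any of which would help to define what this position requires. Also open, from the compounds shown here alone, is how much of a difference in potency lies behind the result, as compound 4 at 100% gives the size of the read-out at a single concentration, and whether a chloro on the other ring of compound 4 would change it further.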